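The compounds below may be only part of what the source reports. "The series", "measured", "known", "first", "only" and "open" are said of these compounds alone.

In a functional assay on MDA-MB-231 cells (Homo sapiens) for cytotoxicity, read by MTT assay, with a stated time of 24 h (on this read-out lower numbers stand for stronger inhibition and higher numbers for weaker inhibition), compound 1 (`O=C(NC1CC1)c1ccc(-c2nc3cccnc3n2C2CCCC2)cc1`) gives 115 nM and compound 2 (`NC(=O)c1ccc(-c2nc3cccnc3n2C2CCCC2)cc1`) gives 8000 nM while compound 3 (`CN(C)C(=O)c1ccc(-c2nc3cccnc3n2C2CCCC2)cc1`) gives 520 nM as the second highest of the three numbers. Compound 4 (`c1cncc(-c2ccc(-c3nc4cccnc4n3C3CCCC3)cc2)c1`) is not yet measured. It carries pyridin-3-yl in place of dimethylcarbamoyl on an aromatic carbon para to a large group.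

Among the measured compounds shown here, no measured step makes this exchange. For the measured compounds named here, the steps that bear on it all change what sits on the amide nitrogen while the carbonyl stays: a 4.5-fold higher number from compound 1 to compound 3 (0.66 log units; beyond the scatter) is modest, whereas a 70-fold higher number from compound 1 to compound 2 (1.84 log units; beyond the scatter) and a 15-fold lower number from compound 2 to compound 3 (1.19 log units; beyond the scatter) are large. Compound 4 has no amide, so these steps give no direction for it. Going by the values given here, they show only that a change at this amide can move the number a long way. No step beyond the scatter is therefore expected in this assay as the central case, though a larger move either way remains possible, and the range is kept wide. The estimated step is a 1.2-fold lower number from compound 3 to compound 4 (0.06 log units; within the scatter) in that central case. For compound 4 the expected value is 450 nM with an estimated range from 100 nM to 2000 nM in this read-out.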

Compound 4, half-maximal inhibitory concentration: > 10000 nM
Compound 4: a limit, no number; the forecaster's own chance of this, stated with the estimate: 3%; at least 22-fold (1.34 log units) between middle value and limit.
By their numbers in this assay, from the lowest: compound 1; then compound 3; then compound 2. At a limit, above all of these: compound 4.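

In this assay compound 4 is read only as a limit, not a number: the limit of > 10000 nM in this assay, at which 1 of the 4 values shown sits.

The earlier compounds shown here varied only what sits on the amide nitrogen, with the carbonyl kept, and all gave numbers, whereas replacing the whole amide with pyridin-3-yl on this aromatic carbon, para to a large group, gives an at least 19-fold higher number from compound 3 to compound 4 (1.28 log units; beyond the scatter), an at least 86-fold higher number from compound 1 to compound 4 (1.93 log units; beyond the scatter) and an at least 1.2-fold higher number from compound 2 to compound 4 (0.09 log units; that floor lies within the scatter). Among the compounds shown, an aromatic ring at this position is therefore not interchangeable with the dimethylcarbamoyl or cyclopropylcarbamoyl groups, even though pyridin-3-yl and dimethylcarbamoyl match in their counted hydrogen-bond donors and acceptors. The floor of the last of these steps lies within the scatter, so the carbamoyl group and pyridin-3-yl cannot be ordered here.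

The compounds shown do not separate the loss of the carbonyl from the entry of the pyridine ring, a question that a plain phenyl ring, a pyridin-4-yl ring, a ketone or a carboxylic acid at this carbon would bear on. From the compounds shown here alone, how far the amide nitrogen can be built out also stays open, for example with a cyclobutyl ring, a longer alkyl chain or a chain ending in an amine.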